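A few compounds are considered here, and "the series" means these few. Any claim that something is new, unique, unknown or untested is made for them only; others in the source may bear on it.

Among the compounds with values here, in an in vitro ADME assay on microsomes from liver (Homo sapiens) for pharmacokinetics, read by LC-MS, with a stated time of 10 min, tested at 1 uM (on this read-out lower numbers stand for slow clearance and higher numbers for fast clearance), compound 1 (`CN1C[C@H](C(=O)Nc2cccc(Cl)c2)[C@@H](c2ccc(/C=C/C(=O)Nc3ccccc3N)cc2)C1`) gives 7 mL/min/kg and compound 2 (`Cc1cc(NC(=O)[C@H]2CN(C)C[C@@H]2c2ccc(/C=C/C(=O)Nc3ccccc3N)cc2)ccc1F`) gives 15 mL/min/kg, the higher of the two numbers so far. Compound 3 (`CN1C[C@H](C(=O)Nc2ccc(F)c(Br)c2)[C@@H](c2ccc(/C=C/C(=O)Nc3ccccc3N)cc2)C1`) departs from compound 2 in one place: bromo in place of methyl on an aromatic carbon. This is bromo in place of methyl on an aromatic carbon, ortho to a fluoro group.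

Within the data shown here, only one measured step bears on this: a 2.1-fold higher number from compound 1 to compound 2 (0.33 log units; beyond the scatter), a modest one. Among the measured compounds shown here, it exchanges 3-chlorophenyl for 4-fluoro-3-methylphenyl, so it is indirect evidence, and no measured pair isolates bromo against methyl. A halogen at that place in compound 1 goes with the lower number, 7 mL/min/kg, so a small move in that direction is expected in this assay, with nothing expected beyond the scatter. The expected step is a 1.5-fold lower number from compound 2 to compound 3 (0.18 log units; within the scatter). For compound 3 the estimated clearance is 10 mL/min/kg, with an expected range of 5 mL/min/kg to 20 mL/min/kg.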

Compound 3, clearance: 15 mL/min/kg
The estimate for compound 3 lay 1.5-fold (0.18 log units) below the measured number; the measured number falls inside the stated range.
By their numbers in this assay, from the lowest: compound 1; then compounds 2 and 3 (each within the scatter of the next).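

In this assay bromo in place of methyl on an aromatic carbon, ortho to a fluoro group, gives no change at the digits printed from compound 2 to compound 3 (within the scatter) and so does not separate the two groups at this position. The 3-bromo-4-fluorophenyl group in place of 3-chlorophenyl gives a 2.1-fold higher number from compound 1 to compound 3 (0.33 log units; beyond the scatter) and shows that a halogen at this place does not by itself go with the low number of compound 1; compound 3 goes against that reading. No measurement available here accounts for either step.

Within the data shown here, whether the step from compound 1 follows the fluoro group or another part of the changed phenyl group stays open, as no pair here isolates it. On these data alone, it is also open whether a nitrile or a methoxy group at this place would stay level with methyl and bromo.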